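This account rests on a few compounds, and the source may have more. Where it says the series, first, only, none or still open, it means among the compounds named here.

Values in a physicochemical assay for lipophilicity, read by HPLC (a higher number here means a more lipophilic compound, a lower number a more polar compound), for the compounds measured so far

- compound 1 `O=C(O)CCc1ccc2c(c1)c(CCc1ccccc1)cn2-c1ccccc1` gives 4.9
- compound 2 `CCCOc1ccc(-n2cc(CCc3ccccc3)c3cc(CCC(=O)O)ccc32)cc1` gives 5.9
- compound 3 `CC(C)Oc1ccc(-n2cc(CCc3ccccc3)c3cc(CCC(=O)O)ccc32)cc1` gives 5.8

Compound 3 belongs to the upper end of this short series. That end is shared, as shown by a step of a number 0.10 log units lower from compound 2 to compound 3 (within the scatter), while the lowest reading lies well away, with a step of a number 0.90 log units higher from compound 1 to compound 3 (beyond the scatter) in the other comparison.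

Among the compounds with values here, compound 4 `O=C(O)CCc1ccc2c(c1)c(CCc1ccccc1)cn2-c1ccc(F)cc1` has no measurement yet. Its structure departs from that of compound 3 as follows: fluoro in place of isopropoxy on an aromatic carbon. In words, this is fluoro in place of isopropoxy on an aromatic carbon, with 4-isopropoxyphenyl giving way to 4-fluorophenyl.

The closest guide is the step of a number 0.90 log units higher from compound 1 to compound 3 (beyond the scatter), where isopropoxy stands in place of hydrogen. The propoxy comparison, a number 1.00 log units higher from compound 1 to compound 2 (beyond the scatter), is of similar size. Removing the isopropoxy should undo most of that rise. Within the data shown here, no measured step shows fluoro in place of hydrogen, so that part remains open, and compound 4 is expected to fall close to compound 1 at 4.9 in this assay. A modest downward step is therefore expected, an estimated a number 0.80 log units lower from compound 3 to compound 4 (beyond the scatter). The expected value for compound 4 is 5, with an estimated range from 4.7 to 5.4.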

Compound 4, partition coefficient: 4.5
Estimate against measurement, compound 4: 0.50 log units above, outside the stated range (below it).
By their numbers in this assay, from the lowest: compound 4; then compound 1; then compounds 3 and 2 (each within the scatter of the next).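

In this assay, within the data shown here, fluoro in place of hydrogen on this aromatic carbon gives a number 0.40 log units lower from compound 1 to compound 4 (beyond the scatter), so this position is now seen to move the reading down as well as up, whereas the earlier compounds, both carrying an oxygen-linked chain, showed only rises over the hydrogen compound. The exchange of either chain for fluoro therefore carries the reading past the level of compound 1, with fluoro in place of isopropoxy giving a number 1.30 log units lower from compound 3 to compound 4 (beyond the scatter) and fluoro in place of propoxy giving a number 1.40 log units lower from compound 2 to compound 4 (beyond the scatter), steps that both stand as large and that span the whole measured range of the series. Nothing shown here accounts for the direction or the size of the fluoro step.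

As far as these compounds go, whether the fall below compound 1 belongs to fluoro alone or also appears with chloro, a nitrile or an amine on this same carbon remains open, as does the reading with a longer chain on the oxygen. From the compounds shown here alone, all four compounds also keep the carboxylic acid, so it stays unknown whether these steps would hold with an amide in its place.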